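Ethylsulfonyl in Place of Cyclopropylcarbonyl

The source may report more compounds than this note shows. Statements on the series, on what has been measured and on what is new or still open speak of the compounds shown alone.

In an ADME assay on the whole organism for metabolic stability, with Rattus norvegicus as the target (on this read-out higher numbers stand for a longer-lived compound and lower numbers for a shorter-lived compound), compound 1 `CC(C)S(=O)(=O)n1cc2c(n1)CN([C@H]1CO[C@H](c3cc(F)ccc3F)[C@@H](N)C1)C2` gives 1.3 h and compound 2 `N[C@H]1C[C@@H](N2Cc3[nH]nc(NC(=O)C4CC4)c3C2)CO[C@@H]1c1cc(F)ccc1F` gives 5.5 h as the higher of the two numbers, a gap beyond the scatter. Compound 3 `CCS(=O)(=O)Nc1n[nH]c2c1CN([C@H]1CO[C@H](c3cc(F)ccc3F)[C@@H](N)C1)C2` awaits measurement. It carries ethylsulfonyl in place of cyclopropylcarbonyl on a nitrogen on an aromatic ring and otherwise matches compound 2. For the measured compounds named here, no measured pair shows this change, so only a small downward move, within the scatter, is expected. The expected step is a 1.6-fold lower number from compound 2 to compound 3 (0.20 log units; within the scatter) in this assay and remains uncertain. Compound 3 is estimated at 3.5 h with 1.3 h to 8 h as its range.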

Compound 3, half-life: 2.1 h
Compound 3: middle estimate off by 1.7-fold (0.22 log units), on the high side; low and high end bracket the measured number.
By their numbers in this assay, from the lowest: compounds 1 and 3 (each within the scatter of the next); then compound 2.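

In this assay, for the compounds shown here, ethylsulfonyl in place of cyclopropylcarbonyl on a nitrogen on an aromatic ring brings a 2.6-fold lower number from compound 2 to compound 3 (0.42 log units; beyond the scatter) and so gives the first single-change reading at this position. The half-life therefore responds to which group this nitrogen carries, and cyclopropylcarbonyl is the longer-lived of the two. Nothing at hand explains the step. The change replaces the carbonyl with a sulfonyl and removes the ring in one step, and the compounds shown cannot separate the two. As far as these compounds go, how an acetyl group, a cyclopropylsulfonyl group or a free amine would read here remains open.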